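Methoxy in place of trifluoromethyl: expected step

This account rests on a few compounds, and the source may have more. Where it says the series, first, only, none or still open, it means among the compounds named here.

In a functional assay on 786-0 cells (Homo sapiens) for inhibition, read by sulforhodamine B assay, with a stated time of 48 h (a higher number here means a weaker inhibitor of growth, a lower number a stronger inhibitor of growth), compound 1 (`CC1(/C=C/c2ccccc2C(F)(F)F)C=CC(=O)O1`) gives 27900 nM and compound 2 (`CC1(/C=C/c2ccc(C(F)(F)F)cc2)C=CC(=O)O1`) gives 34000 nM, two values within the scatter of each other. Compound 3 (`COc1cc(OC)c(/C=C/C2(C)C=CC(=O)O2)c(OC)c1`) gives 459000 nM, beyond the scatter from compound 2, which therefore stands second highest of the three and level with compound 1. Compound 4 (`COc1ccc(/C=C/C2(C)C=CC(=O)O2)cc1`) carries methoxy in place of trifluoromethyl on an aromatic carbon, para to a group of 9 heavy atoms: methoxy in place of trifluoromethyl on an aromatic carbon. Among the measured compounds shown here, no measured pair isolates this change. A moderate rise is expected, towards weaker inhibition of growth, stopping short of compound 3, which bears methoxy groups and gives 459000 nM. The expected step is a 2.1-fold higher number from compound 2 to compound 4 (0.31 log units; beyond the scatter). For compound 4 the estimate is 70000 nM, with an expected range of 25000 nM to 200000 nM.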

Compound 4, concentration for total growth inhibition: > 1000000 nM
Compound 4 gave a limit, no number (the forecaster's own chance of this, stated with the estimate: 10%); middle value at least 14-fold (1.15 log units) away from the limit.
By their numbers in this assay, from the lowest: compounds 1 and 2 (each within the scatter of the next); then compound 3. At a limit, above all of these: compound 4.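

Methoxy in place of trifluoromethyl on an aromatic carbon, para to a group of 9 heavy atoms, is a large change at this position, with an at least 29-fold higher number from compound 2 to compound 4 (1.46 log units; beyond the scatter). In this assay compound 4 gives > 1000000 nM, which is a limit and not a number. From the compounds shown here alone, the step therefore fixes only a minimum size, and its full size stays unknown: the limit of > 1000000 nM in this assay, at which 1 of the 4 values shown sits.

The compounds shown leave open how a hydroxyl, an amine or a nitrile would read at this position. They also leave open whether trifluoromethyl is specifically required here.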